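The source may report more compounds than this note shows. Statements on the series, on what has been measured and on what is new or still open speak of the compounds shown alone.

Working notes on the series

Three compounds of the shared core carry a measured value in a functional assay on HL-60 cells (Homo sapiens) for inhibition, read by MTT assay, with a stated time of 72 h; on this read-out higher numbers stand for weaker inhibition and lower numbers for stronger inhibition. Compound 1 `Cc1nc(-c2ccccc2)c(C(=O)N2CCN(c3c(C)cccc3C)CC2)o1` gives 146 nM in this assay. Compound 2 `COc1cc(OC)cc(N2CCN(C(=O)c3sc(C)nc3-c3ccccc3F)CC2)c1` gives 96.8 nM, and compound 3 `CCc1nc(-c2cccc(F)c2)c(C(=O)N2CCN(c3cccc(Cl)c3)CC2)o1` gives 317 nM. Among these three numbers compound 1 stands second highest: the gap to compound 2 lies within the usual scatter of this assay, so the two cannot be ordered, while compound 3 sits beyond the scatter on the higher side, that is, the weaker side of the read-out.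

Compound 4 `Cc1ccc(N2CCN(C(=O)c3oc(C)nc3-c3ccccc3)CC2)c(C)c1` has not yet been measured in this assay. It is built from the same atoms as compound 1, joined differently: 2,4-dimethylphenyl in place of 2,6-dimethylphenyl on an amine nitrogen in a ring. The change touches only the arrangement of the two methyl groups on the phenyl ring that sits on the ring nitrogen of the core. Among the measured compounds shown here, no measured pair differs in one place, so there is no matched step from which the size of this rearrangement could be read off.

With so little to go on, the expectation for compound 4 rests on compound 1 alone, whose value of 146 nM is taken as the anchor. The step from compound 1 to compound 4 is expected to be a 1.0-fold higher number from compound 1 to compound 4 (0.01 log units; within the scatter), which is no more than the scatter in either direction. Compound 4 is therefore estimated at 150 nM in this assay, with a range from 60 nM to 400 nM.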

Compound 4, half-maximal inhibitory concentration: 101 nM
Beside the measured number, compound 4's estimate is 1.5-fold (0.17 log units) above it; low and high end bracket the measured number.
By their numbers in this assay, from the lowest: compounds 2, 4 and 1 (each within the scatter of the next); then compound 3.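

Among the compounds shown here, the first matched step comes from the phenyl ring on the ring nitrogen of the core: in this assay, 2,4-dimethylphenyl in place of 2,6-dimethylphenyl gives a 1.4-fold lower number from compound 1 to compound 4 (0.16 log units; within the scatter). With the atoms unchanged, this rearrangement of the two methyl groups leaves the read-out within the usual scatter, so compound 1 and compound 4 cannot be ordered, and this one pair shows that the 2,6-dimethylphenyl arrangement is not required at this position for a value of this size. Nothing on hand bears on why the two arrangements read alike.

Compounds 2 and 3 differ from compound 1 in more than one place, so they cannot show what a different group on this phenyl ring does alone. Going by these compounds, it remains open whether an amine, a carboxylic acid or a longer chain in place of one methyl group would stay within the scatter of compound 1 or move the read-out beyond it, in either direction.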